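Tertiary thiophene amine replaces benzylamine on the piperidine carbon

This account rests on a few compounds, and the source may have more. Where it says the series, first, only, none or still open, it means among the compounds named here.

The measured compounds:
compound 1 `c1ccc(CNC2CCN(CCCc3c[nH]c4ccc(-n5cnnc5)cc34)CC2)cc1`: 4.6 nM
compound 2 `COC[C@H](NC1CCN(CCCc2c[nH]c3ccc(Cn4cncn4)cc23)CC1)c1ccc(F)cc1`: 5 nM
compound 3 `c1ccc(C2CCCCN2C2CCN(CCCc3c[nH]c4ccc(-n5cnnc5)cc34)CC2)cc1`: 1.9 nM

In an assay on CHO cells for displacement of a labelled ligand from 5-hydroxytryptamine receptor 1D (Homo sapiens) (a higher number here means a weaker inhibitor, a lower number a stronger inhibitor), compound 1 gives 4.6 nM, the second highest of the three numbers. Compound 2 sits nearest to it, and the gap between the two lies within the scatter, so no order can be read between them. Compound 3 stands furthest away, with a lower number than compound 1 by a gap that lies beyond the scatter.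

Compound 4 `CN(Cc1ccsc1)C1CCN(CCCc2c[nH]c3ccc(-n4cnnc4)cc23)CC1` shares the core of compound 1 and differs from it in one place: methyl((thiophen-3-yl)methyl)amino in place of benzylamino on a saturated ring carbon. Within the data shown here, the change removes the single hydrogen-bond donor and exchanges the six-membered aromatic ring for a five-membered one bearing a hetero atom. Compound 3, which also carries no donor at this place, gives 1.9 nM, so a tertiary amine there is compatible with a low number. A step of no more than the scatter is expected, with no clear direction, and the estimated step of a 1.2-fold lower number from compound 1 to compound 4 (0.06 log units; within the scatter) reflects that. Compound 4 is therefore expected to give about 4 nM in this assay, within a range from 1.5 nM to 12 nM.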

Compound 4, half-maximal inhibitory concentration: 1.5 nM
Compound 4: middle estimate off by 2.7-fold (0.43 log units), on the high side; the measured number falls inside the stated range.
By their numbers in this assay, from the lowest: compounds 4 and 3 (each within the scatter of the next); then compounds 1 and 2 (each within the scatter of the next).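

In this assay the replacement gives a 3.1-fold lower number from compound 1 to compound 4 (0.49 log units; beyond the scatter), which shows that the hydrogen-bond donor of benzylamino is not required for a low number at this saturated ring carbon, and that a five-membered aromatic ring with a sulfur atom can stand in place of the six-membered carbon ring. Compound 4 and compound 3, neither of which has a donor at this place, lie within the scatter of each other despite their different tertiary amines, and both stand beyond the scatter from compound 1. No accompanying measurement accounts for the step.

The compounds shown leave open whether the step follows from the added methyl, from the thiophene, or from both. Methyl(benzyl)amino and (thiophen-3-yl)methylamino at this place would separate the two.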